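Replacing the 4-Hydroxycyclohexyl Group: Expected Lipophilicity

The source may report more compounds than this note shows. Statements on the series, on what has been measured and on what is new or still open speak of the compounds shown alone.

Compound 3 `CC[C@@H](c1ccccc1)n1nc(C(=O)NC)cc1C(=O)N[C@H]1CC[C@H](O)CC1` has only "not determined" (no result reported) in a physicochemical assay for lipophilicity (a lower number here means a more polar compound, a higher number a more lipophilic compound), so nothing is known about where it stands. Compound 4 `CC[C@@H](c1ccccc1)n1nc(C(=O)NC)cc1C(=O)N[C@H]1[C@@H]2C[C@@H](O)C[C@@H]21` differs from it by a group of 7 heavy atoms (6 carbon, 1 oxygen; one three-membered non-aromatic ring of carbon only, one five-membered non-aromatic ring of carbon only) in place of a group of 7 heavy atoms (6 carbon, 1 oxygen; one six-membered non-aromatic ring of carbon only), on an amide-type nitrogen. Among the measured compounds shown here, no measured step follows this exact change, so the only guidance comes from compounds that already carry the entering group with its three-membered and five-membered rings. Compound 1 `CNC(=O)c1cc(C(=O)N[C@H]2[C@@H]3C[C@@H](O)C[C@@H]32)n([C@@H](C)c2cccc(Cl)c2)n1` gives 3.4 in this assay, and compound 2 `CNC(=O)c1cc(C(=O)N[C@H]2[C@@H]3C[C@@H](O)C[C@@H]32)n([C@@H](C)c2ccccc2)n1` gives 3.2; the step of a number 0.20 log units lower from compound 1 to compound 2 (within the scatter) shows that these two are close. Compound 4 shares that entering group and an aromatic ring without chloro with compound 2, whose reading of 3.2 is the nearest guide, and a similar result is expected. Compound 4 is estimated at 3.5, within a range from 3 to 4.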

Compound 4, distribution coefficient: 3.3
Beside the measured number, compound 4's estimate is 0.20 log units above it; the measured number falls inside the stated range.
By their numbers in this assay, from the lowest: compounds 2, 4 and 1 (each within the scatter of the next).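

Among compounds carrying the entering ring group, the group on the aromatic nitrogen can change without a step leaving the scatter in this assay: methyl in place of hydrogen on the saturated chain carbon gives a number 0.10 log units higher from compound 2 to compound 4 (within the scatter), and 1-phenylpropyl in place of 1-(3-chlorophenyl)ethyl gives a number 0.10 log units lower from compound 1 to compound 4 (within the scatter). No measurement offers an explanation for these readings.

Going by these compounds, compound 3 has no number, so the step from it to compound 4 cannot be read, and the effect of replacing 4-hydroxycyclohexyl stays open. On these data alone, how an amine or a carboxylic acid in place of the hydroxy group would read also remains unknown.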